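The compounds below may be only part of what the source reports. "The series", "measured", "known", "first", "only" and "open" are said of these compounds alone.

Measured compounds:
- compound 1, `CC(C)[C@H](NC(=O)COc1cccc2ccccc12)C(=O)N[C@@H](CC(=O)O)C(=O)COc1ccc2ccccc2c1`; in a functional assay with Homo sapiens as the target (a lower number here means a stronger inhibitor, a higher number a weaker inhibitor), compound 1 gives 15900 nM
- compound 2, `CC(C)[C@H](NC(=O)COc1cccc2ccccc12)C(=O)N[C@@H](CC(=O)O)C(=O)COc1ccc(C(F)(F)F)cc1`; in this assay compound 2 gives 12300 nM
- compound 3, `CC(C)[C@H](NC(=O)COc1cccc2ccccc12)C(=O)N[C@@H](CC(=O)O)C(=O)COc1cccc(F)c1`; in this assay compound 3 gives 12000 nM

All three share the same core and differ only in the aryl group on an oxygen on a saturated carbon. Compound 2 sits with the other two inside the usual scatter: the step of a 1.3-fold lower number from compound 1 to compound 2 (0.11 log units; within the scatter) and the step of a 1.0-fold lower number from compound 2 to compound 3 (0.01 log units; within the scatter) are both within it, as is a 1.3-fold lower number from compound 1 to compound 3 (0.12 log units; within the scatter). No ordering among the three compounds can be claimed from these numbers.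

Compound 4, `CC(C)[C@H](NC(=O)COc1cccc2ccccc12)C(=O)N[C@@H](CC(=O)O)C(=O)COc1ccc(F)c(F)c1`, is not yet measured. Relative to compound 2 the change is 3,4-difluorophenyl in place of 4-(trifluoromethyl)phenyl on an oxygen on a saturated carbon

For the measured compounds named here, the steps that bear on it are the three exchanges of the aryl group already measured, each of them within the scatter. Going by the values given here, every change at this position so far, whether to naphthalen-2-yl, 4-(trifluoromethyl)phenyl or 3-fluorophenyl, has left the number essentially unchanged, so for compound 4 no step beyond the scatter is expected in this assay, and the step of a 1.0-fold higher number from compound 2 to compound 4 (0.01 log units; within the scatter) is the estimate.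

For compound 4 the expected value in this assay is 12500 nM, with a range of 6000 nM to 26000 nM.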

Compound 4, half-maximal inhibitory concentration: 16200 nM
Estimate against measurement, compound 4: 1.3-fold (0.11 log units) below, and the stated range covers the measured number.
By their numbers in this assay, from the lowest: compounds 3, 2, 1 and 4 (each within the scatter of the next).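

In this assay the aryl group on an oxygen on a saturated carbon now takes a fourth form, 3,4-difluorophenyl, and a 1.3-fold higher number from compound 2 to compound 4 (0.12 log units; within the scatter) and a 1.4-fold higher number from compound 3 to compound 4 (0.13 log units; within the scatter) and a 1.0-fold higher number from compound 1 to compound 4 (0.01 log units; within the scatter) all lie within the scatter, so compound 4 joins the other three without any ordering among them. The step from compound 3 adds a new kind of change, fluoro in place of hydrogen on an aromatic carbon, and the exchange from compound 2 replaces 4-(trifluoromethyl)phenyl with a group of fewer heavy atoms, yet neither gives a readable difference, which extends the flat picture at this position to a ring bearing two fluoro groups. No measurement on hand bears on why the number holds so steady across these groups.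

As far as these compounds go, all four compounds carry a carbon-only aromatic ring here, so it stays open whether an amine or a carboxylic acid on that ring, or a longer chain between the oxygen and the ring, would give a step beyond the scatter. The rest of the shared core is constant across the four compounds, which leaves open whether a change elsewhere in it would move the number.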